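The compounds below may be only part of what the source reports. "The series", "measured", "known", "first", "only" and "open" are said of these compounds alone.

Measured so far in a physicochemical assay for solubility, read by spectrophotometry, measured as kinetic solubility, at pH 8, tested at 500 uM; on this read-out lower numbers stand for lower solubility and higher numbers for higher solubility:
- Compound 1 `CN1CCC(CNS(=O)(=O)c2ccccc2Nc2cc(-c3ccc4ccn(C)c4c3)c3nccnc3c2)C1` gives 35 ug/mL
- Compound 2 `CNS(=O)(=O)c1ccccc1Nc1cc(-c2ccc3ccn(C)c3c2)c2nccnc2c1` gives 2 ug/mL
- Compound 3 `Cn1ccc2ccc(-c3cc(Nc4ccccc4S(=O)(=O)N4CCOCC4)cc4nccnc34)cc21` gives 5 ug/mL

Compound 3 holds the second highest of these three numbers, with compound 2 lower and compound 1 higher. The change to compound 4 `CN1CCC(NS(=O)(=O)c2ccccc2Nc2cc(-c3ccc4ccn(C)c4c3)c3nccnc3c2)C1` is (1-methylpyrrolidin-3-yl)amino in place of morpholin-4-yl on a sulfonyl sulfur and puts (1-methylpyrrolidin-3-yl)amino in place of morpholin-4-yl on a sulfonyl sulfur. Going by the values given here, no measured compound carries that group, but compound 1 carries the close ((1-methylpyrrolidin-3-yl)methyl)amino. The nearest evidence is the modest 7.0-fold lower number from compound 1 to compound 3 (0.85 log units; beyond the scatter) and the large 18-fold lower number from compound 1 to compound 2 (1.24 log units; beyond the scatter) points the same way, while the modest 2.5-fold higher number from compound 2 to compound 3 (0.40 log units; beyond the scatter) adds little. Read in reverse, these suggest a modest rise in this assay with an estimated 5.6-fold higher number from compound 3 to compound 4 (0.75 log units; beyond the scatter) as the expected step. Compound 4 is expected at 28 ug/mL (10 ug/mL to 70 ug/mL).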

Compound 4, solubility: 26 ug/mL
Estimate against measurement, compound 4: 1.1-fold (0.03 log units) above; the measured number falls inside the stated range.
By their numbers in this assay, from the lowest: compound 2; then compound 3; then compounds 4 and 1 (each within the scatter of the next).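

In this assay the step of a 5.2-fold higher number from compound 3 to compound 4 (0.72 log units; beyond the scatter) sets (1-methylpyrrolidin-3-yl)amino on a sulfonyl sulfur above morpholin-4-yl, and the step of a 13-fold higher number from compound 2 to compound 4 (1.11 log units; beyond the scatter) sets 1-methylpyrrolidin-3-yl above methyl on the sulfonamide nitrogen. The step of a 1.3-fold lower number from compound 1 to compound 4 (0.13 log units; within the scatter) puts 1-methylpyrrolidin-3-yl in place of (1-methylpyrrolidin-3-yl)methyl, and the extra carbon of compound 1 makes no readable difference. No measured evidence accounts for these steps.

The compounds shown leave open whether the ring is needed or an open-chain amine such as 2-(dimethylamino)ethyl on the sulfonamide nitrogen would serve equally. They also leave open how a six-membered 1-methylpiperidin-4-yl group would compare.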